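Ethylsulfonamide aryl series: imidazoline replaced by imidazolylthio

The source may hold more compounds than are shown below. What is called first, only, known or untested is meant among the compounds shown, and "the series" means these compounds.

Measured so far in an assay on isolated protein for binding affinity to Alpha-1A adrenergic receptor (Rattus norvegicus), read by radioligand binding; on this read-out lower numbers stand for stronger inhibition and higher numbers for weaker inhibition:
compound 1, `CCS(=O)(=O)Nc1cccc2c1CCCC2CNC`, 1380 nM
compound 2, `CCS(=O)(=O)Nc1cccc(-c2c[nH]cn2)c1`, < 10000 nM (a limit of this assay, not a number)
compound 3, `CCS(=O)(=O)Nc1cccc(NC2=NCCN2)c1`, 2950 nM

Compound 3 carries the highest of the two numbers in this assay; compound 1 sits lower, and that gap lies beyond the scatter. Compound 2 gives only a limit in this assay, so the step that the limit leaves unreadable from compound 2 to compound 3 cannot be read because of the limit of < 10000 nM in this assay, at which 1 of the 3 values shown sits.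

Compound 4 is `CCS(=O)(=O)Nc1cccc(Sc2c[nH]cn2)c1`. It differs from compound 3 in one place: a group of 6 heavy atoms (3 carbon, 2 nitrogen, 1 sulfur; one five-membered aromatic ring with 2 hetero atoms) in place of a group of 6 heavy atoms (3 carbon, 3 nitrogen; one five-membered non-aromatic ring with 2 hetero atoms), on an aromatic carbon. Among the measured compounds shown here, the only measured step that touches the same position is the one from compound 2 to compound 3, and its size is unreadable, so no direction for the new step can be taken from the data. Compound 4 shares its five-membered aromatic ring with compound 2, which gave only a limit, and its open chain link is new to the set.

Compound 4 is therefore expected near compound 3, at an estimated 4000 nM, range 1200 nM to 13000 nM. The step of a 1.4-fold higher number from compound 3 to compound 4 (0.13 log units; within the scatter) is expected to stay close to the scatter.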

Compound 4, inhibition constant: < 10000 nM
Compound 4 ended at the assay's limit; the forecaster's own chance of this, stated with the estimate: 30%; the middle value is on the limit's open side.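

Neither the step from compound 3 to compound 4 nor the step from compound 2 to compound 4 can be read in this assay, because each involves a limit: the limit of < 10000 nM in this assay, at which 2 of the 4 values shown sit.

The compounds shown leave open how (1H-imidazol-4-yl)sulfanyl in compound 4 compares with 1H-imidazol-4-yl in compound 2 or with the group it replaces in compound 3.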